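The source may report more compounds than this note shows. Statements on the series, on what has been measured and on what is new or still open speak of the compounds shown alone.

Of the compounds shown here, three have so far been tested in a functional assay on MGC-803 cells (Homo sapiens) for inhibition, read by MTT assay, with a stated time of 48 h; on this read-out lower numbers stand for stronger inhibition and higher numbers for weaker inhibition. Compound 1 `C/C=C/C(=O)N(Cc1cccc(O)c1)c1cc(OC)c(OC)c(OC)c1` gives 14100 nM, compound 2 `C/C=C/C(=O)N(Cc1cc(OC)c(OC)c(OC)c1)c1ccc(OC)c(O)c1` gives 6150 nM, and compound 3 `C#CC(=O)N(Cc1ccc(OC)c(O)c1)c1cc(OC)c(OC)c(OC)c1` gives 170 nM. Compound 2 thus holds the second highest of the three numbers: its nearest neighbour is compound 1, whose number is higher by more than the usual scatter, and its furthest is compound 3, whose number is far lower. Compound 4 `COc1ccc(N(Cc2cc(OC)c(OC)c(OC)c2)C(=O)CCl)cc1O` has not yet been measured in this assay. It differs from compound 2 in one place: chloromethyl in place of prop-1-en-1-yl on a carbonyl carbon. Within the data shown here, the only compound here without a prop-1-en-1-yl group, compound 3, gives a much lower number, although it differs from compound 2 in more than one place. On that basis compound 4 is expected to give a lower number than compound 2, the expected step of a 10-fold lower number from compound 2 to compound 4 (1.01 log units; beyond the scatter) lying beyond the scatter. The estimate for compound 4 is 600 nM, with a range from 150 nM to 2500 nM.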

Compound 4, half-maximal inhibitory concentration: 24500 nM
Estimate against measurement, compound 4: 41-fold (1.61 log units) below; the whole stated range lies below it.
By their numbers in this assay, from the lowest: compound 3; then compound 2; then compounds 1 and 4 (each within the scatter of the next).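

In this assay, the carbonyl carbon now has its first comparison that differs in one place: chloromethyl in place of prop-1-en-1-yl gives a 4.0-fold higher number from compound 2 to compound 4 (0.60 log units; beyond the scatter). The group on this carbon therefore changes the read-out, and losing prop-1-en-1-yl does not in itself bring a lower number. No measurement here gives a reason for this step.

As far as these compounds go, whether a plain methyl or an aminomethyl group on the same carbon would give a higher or lower number remains open. So does how much of the low number of compound 3 belongs to this position, as it differs from compound 2 in more than one place.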